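The compounds below may be only part of what the source reports. "The series", "measured", "known", "first", "only" and "open" are said of these compounds alone.

Measured so far in a functional assay on HEK293 cells for agonist activity at Bombesin receptor subtype-3 (Mus musculus), read by luminescence and calcium flux, with a stated time of 10 min; a lower number here means that less compound is needed, a higher number that more compound is needed for the effect:
- compound 1 `CCC(C)(C)Cc1c[nH]c(CCc2ccc(-c3cccc(C#N)n3)cc2)n1`: 115 nM
- compound 2 `c1ccc(-c2ccc(CCc3nc(CC4CCCC4)c[nH]3)cc2)nc1`: 103 nM

Compound 1 and compound 2 sit within the usual scatter of each other in this assay, so the two measured compounds give no direction to read from; compound 1 simply carries the higher of two numbers that cannot be told apart. Both compounds keep the same core and the same aryl-pyridyl pairing on the ring that bears the ethylene link.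

Compound 3 `CCC(C)(C)Cc1c[nH]c(CCc2ccc(N3CCCCC3)cc2)n1` has not yet been measured. It differs from compound 1 in one place: piperidin-1-yl in place of 6-cyanopyridin-2-yl on an aromatic carbon. Among the compounds with values here, no pair of measured compounds shares this change, so there is no measured step to lean on. A step in this assay toward a higher number, beyond the scatter, is expected, estimated as a 4.3-fold higher number from compound 1 to compound 3 (0.64 log units; beyond the scatter). For compound 3 the estimate in this assay is 500 nM, expected to fall between 150 nM and 2000 nM.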

Compound 3, half-maximal effective concentration: 133 nM
Estimate against measurement, compound 3: 3.8-fold (0.58 log units) above; the whole stated range lies above it.
By their numbers in this assay, from the lowest: compounds 2, 1 and 3 (each within the scatter of the next).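

In this assay, placing piperidin-1-yl instead of 6-cyanopyridin-2-yl on the aromatic carbon para to a large group gives a 1.2-fold higher number from compound 1 to compound 3 (0.06 log units; within the scatter). Within this pair, neither the six-membered aromatic ring nor the nitrile of the group that leaves is needed to keep the number within the scatter of compound 1, so this position accepts a non-aromatic ring without a measurable step. Nothing available explains why the two groups read alike.

From the compounds shown here alone, whether this holds for smaller or open-chain groups at the same position, such as a dimethylamino group, or for a carboxylic acid, remains open. Also open, going by these compounds, is whether piperidin-1-yl behaves the same way when the cyclopentylmethyl group of compound 2 stands on the core.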